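A few compounds are considered here, and "the series" means these few. Any claim that something is new, unique, unknown or untested is made for them only; others in the source may bear on it.

Compound 1 `Fc1ccccc1-c1cc(COc2ccccc2-c2nc3ccccc3s2)on1` and compound 2 `Clc1ccc(-c2cc(COc3ccccc3-c3nc4ccccc4s3)on2)cc1` share one core and differ only in the aryl group attached to it. In an ADME assay on MCF-10A cells (Homo sapiens) for cytotoxicity, read by MTT assay, with a stated time of 24 h (on this read-out higher numbers stand for weaker inhibition and lower numbers for stronger inhibition), compound 1 gives 42500 nM, and compound 2 gives 38800 nM. For the measured compounds named here, the one step measured so far, a 1.1-fold lower number from compound 1 to compound 2 (0.04 log units; within the scatter), is small. Compound 2 therefore stands at the lower of the two numbers seen in this assay, with compound 1 nearest and within the scatter of it, so the two cannot be ordered.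

Compound 3 `Cc1ccc(-c2cc(COc3ccccc3-c3nc4ccccc4s3)on2)cc1` is the next member of the series, still unmeasured in this assay. Its difference from compound 2 is methyl in place of chloro on an aromatic carbon. Going by the values given here, the only measured step that bears on this change is the exchange of one aryl substituent for another between compound 1 and compound 2, and that step stayed within the scatter. With no sign in the data that a single substituent at this place moves the read-out, the step from compound 2 to compound 3 is expected to be no larger than the scatter, a 1.0-fold higher number from compound 2 to compound 3 (0.01 log units; within the scatter). Compound 3 is accordingly estimated to give 40000 nM in this assay, with a range from 20000 nM to 80000 nM.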

Compound 3, half-maximal inhibitory concentration: 26400 nM
Compound 3: middle estimate off by 1.5-fold (0.18 log units), on the high side, within the range that was stated.
By their numbers in this assay, from the lowest: compounds 3, 2 and 1 (each within the scatter of the next).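

In this assay, the exchange of chloro for methyl gives a 1.5-fold lower number from compound 2 to compound 3 (0.17 log units; within the scatter) and so adds something the first pair could not show: with the place held fixed, on the aromatic carbon para to a large group, a change of the substituent alone also stays within the scatter. The second new comparison, 4-methylphenyl in place of 2-fluorophenyl, gives a 1.6-fold lower number from compound 1 to compound 3 (0.21 log units; within the scatter) and is likewise within the scatter, so the 2-fluorophenyl, 4-chlorophenyl and 4-methylphenyl compounds remain unresolved on this read-out, and no effect of this position can be claimed from them. No measurement shown here offers any account of this result.

The compounds shown carry only a small single-atom substituent at this place or a fluoro group elsewhere on the aryl ring, so whether an amine, a carboxylic acid or a longer chain at this place would move the number beyond the scatter remains open. Also open, as far as these compounds go, is how the read-out responds to any change in the shared core, since all three compounds keep it intact.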